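The source may hold more compounds than are shown below. What is called first, only, known or untested is meant among the compounds shown, and "the series" means these compounds.

Compound 1, `CN(C)CCn1cnnc1-c1cc(Oc2ccc(NC(=O)N/N=C/c3ccc(O)c(Br)c3)cc2F)ccn1`, gives 450 nM in a functional assay on HT-29 cells (Homo sapiens) for cytotoxicity, read by MTT assay, with a stated time of 72 h; on this read-out higher numbers stand for weaker inhibition and lower numbers for stronger inhibition.
Compound 2, `CN(C)CCn1cnnc1-c1cc(Oc2ccc(NC(=O)N/N=C/c3ccc(F)cc3)cc2F)ccn1`, gives 1370 nM.
Compound 3, `CN(C)CCn1cnnc1-c1cc(Oc2ccc(NC(=O)N/N=C/c3ccc(Cl)cc3)cc2F)ccn1`, gives 530 nM.

Among these three measured compounds, compound 1 carries the lowest number: compound 3 sits close to it, within the usual scatter, while compound 2 sits further off. The two measured steps that start from compound 1 both exchange the same group, the 3-bromo-4-hydroxyphenyl on a carbon with a double bond to nitrogen. Putting a 4-fluorophenyl there gave a 3.0-fold higher number from compound 1 to compound 2 (0.48 log units; beyond the scatter), and putting a 4-chlorophenyl there gave a 1.2-fold higher number from compound 1 to compound 3 (0.07 log units; within the scatter). Between those two, a 2.6-fold lower number from compound 2 to compound 3 (0.41 log units; beyond the scatter) shows that the choice of group on that aromatic ring matters by a modest amount.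

Compound 4, `CN(C)CCn1cnnc1-c1cc(Oc2ccc(NC(=O)N/N=C/c3ccc(O)cc3O)cc2F)ccn1`, is built by a change at the same position: 2,4-dihydroxyphenyl in place of 3-bromo-4-hydroxyphenyl on a carbon with a double bond to nitrogen. Among the measured compounds shown here, no measured compound carries two hydroxy groups on that ring, so the direction rests only on the observation that every replacement of the 3-bromo-4-hydroxyphenyl so far left the number unchanged or higher. A step of a 1.6-fold higher number from compound 1 to compound 4 (0.19 log units; within the scatter) is therefore expected, with no strong gain anticipated. The estimate for compound 4 is 700 nM, spanning roughly 250 nM to 2000 nM.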

Compound 4, half-maximal inhibitory concentration: 52600 nM
Estimate against measurement, compound 4: 75-fold (1.88 log units) below; measured number above the stated range.
By their numbers in this assay, from the lowest: compounds 1 and 3 (each within the scatter of the next); then compound 2; then compound 4.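

The 2,4-dihydroxyphenyl group stands far apart from the other three groups at this position: in this assay, it gives a 120-fold higher number from compound 1 to compound 4 (2.07 log units; beyond the scatter), while the earlier exchanges there produced modest steps or none beyond the scatter. The large jump is not tied to one reference compound, as the same exchange gives a 99-fold higher number from compound 3 to compound 4 (2.00 log units; beyond the scatter) and starting from the 4-fluorophenyl group gives a 38-fold higher number from compound 2 to compound 4 (1.58 log units; beyond the scatter), so this ring can change the number far more than the first three compounds revealed. Both 3-bromo-4-hydroxyphenyl and 2,4-dihydroxyphenyl count 8 heavy atoms, so atom count alone does not separate them, and nothing available explains the loss.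

Compound 4 differs from compound 1 by lacking the bromine and by carrying a second hydroxy group, and the compounds shown cannot say which of these features goes with the higher number. A ring with a single hydroxy group and no bromine, or one with methoxy groups or an amine in place of the hydroxy groups, would help to pull those features apart.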